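Bromo to chloro on the sulfonyl aryl: cytotoxicity notes

This account rests on a few compounds, and the source may have more. Where it says the series, first, only, none or still open, it means among the compounds named here.

Measured so far, in a functional assay on DU-145 cells (Homo sapiens) for cytotoxicity, read by MTT assay; on this read-out higher numbers stand for weaker inhibition and lower numbers for stronger inhibition:
- compound 1 `CC(O)(CS(=O)(=O)c1ccc(Br)cc1)c1nc(-c2ccc([N+](=O)[O-])c(C(F)(F)F)c2)no1`: compound 1 gives > 100000 nM, which is a limit of the assay and not a number.
- compound 2 `CC(O)(CS(=O)(=O)c1ccc(Cl)cc1)c1nc(-c2ccc(Cl)cc2)no1`: compound 2 gives > 100000 nM, again only a limit.

Among the measured compounds shown here, compound 1 thus has no fixed place on these numbers: only a limit is known for it, and the one other value shown is also a limit, so the whole picture is the limit of > 100000 nM in this assay, at which 2 of the 2 values shown sit. For the measured compounds named here, no step between measured compounds can be drawn from this. Compound 3 `CC(O)(CS(=O)(=O)c1ccc(Cl)cc1)c1nc(-c2ccc([N+](=O)[O-])c(C(F)(F)F)c2)no1` differs from compound 1 by chloro in place of bromo on an aromatic carbon. With both measured compounds at the limit, compound 3 is expected to show no step beyond the scatter: a step that the limit leaves unreadable from compound 1 to compound 3. Compound 3 is most likely expected to come back as a limit too. The estimate for compound 3 in this assay is 150000 nM, within a range from 50000 nM to 500000 nM.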

Compound 3, half-maximal inhibitory concentration: 91000 nM
Beside the measured number, compound 3's estimate is 1.6-fold (0.22 log units) above it; the measured number falls inside the stated range.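

In this assay, among the compounds shown here, compound 3 gives 91000 nM, the only value so far that is a number and not a limit. The change from (4-bromophenyl)sulfonyl to (4-chlorophenyl)sulfonyl, on an aromatic carbon para to a large group, gives an at least 1.0-fold lower number from compound 1 to compound 3 (0.04 log units; that floor lies within the scatter), so this position shows no gain that can be told from the scatter. Compound 1 remains only a limit, and most of the series still sits there: the limit of > 100000 nM in this assay, at which 2 of the 3 values shown sit.

Going by these compounds, how far compound 1 truly lies from compound 3 stays open, since the limit hides the size of the step. Also open, on these data alone, is whether an amine or a methoxy group in place of the halogen would bring a number clearly below this limit.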